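This account rests on a few compounds, and the source may have more. Where it says the series, first, only, none or still open, it means among the compounds named here.

- compound 1 `CC/C(=C(/c1ccc(/C=C/C(=O)O)cc1)c1ccc(O)nc1)c1ccccc1`: "not determined" (no result reported)
- compound 2 `CC/C(=C(/c1ccc(/C=C/C(=O)O)cc1)c1ccc2[nH]ncc2c1)c1ccc(Cl)cc1`: 15 nM

Among the measured compounds shown here, in a functional assay on MCF7 cells (Homo sapiens) for cytotoxicity, read by CellTiter-Glo, with a stated time of 5 days (on this read-out lower numbers stand for stronger inhibition and higher numbers for weaker inhibition), compound 2 holds the only number, so its standing cannot be judged against another compound. Compound 3 `CC/C(=C(/c1ccc(/C=C/C(=O)O)cc1)c1ccc2[nH]ncc2c1)c1ccc(C#N)cc1C` differs from compound 2 in one place: 4-cyano-2-methylphenyl in place of 4-chlorophenyl on a double-bonded chain carbon bound to a double-bonded chain carbon and a saturated chain carbon. For the measured compounds named here, no measured pair shows the effect of this swap, so the only anchor is compound 2 at 15 nM. The expected outcome is a 1.3-fold lower number from compound 2 to compound 3 (0.10 log units; within the scatter), with no shift beyond the scatter in either direction. The estimate for compound 3 is 12 nM, with an expected range of 3 nM to 50 nM.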

Compound 3, half-maximal inhibitory concentration: 5 nM
Beside the measured number, compound 3's estimate is 2.4-fold (0.38 log units) above it; the range from low to high includes it.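

In this assay, among the compounds shown here, 4-cyano-2-methylphenyl in place of 4-chlorophenyl gives a 3.0-fold lower number from compound 2 to compound 3 (0.48 log units; beyond the scatter) and so provides the first readable step. The place on a double-bonded chain carbon bound to a double-bonded chain carbon and a saturated chain carbon therefore responds to a change of aromatic group, with 4-chlorophenyl not the best group seen there. Nothing available explains this gain.

The swap alters the nitrile, methyl and chlorine together, so their separate contributions remain unresolved. A 4-cyanophenyl or 4-chloro-2-methylphenyl group at this place would separate them.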